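Fluoro removal repeated across two drawn configurations

The compounds below may be only part of what the source reports. "The series", "measured", "known", "first", "only" and "open" are said of these compounds alone.

Compound 1 `C/C(=N/NC(=S)Nc1ccccc1F)c1ccccn1` and compound 3 `C/C(=N\NC(=S)Nc1ccccc1F)c1ccccn1` share every atom and bond and differ only in how one double bond is drawn: the two compounds have the same atoms and bonds and differ only in configuration as drawn: 1 of 1 stereo elements differ; a double bond is drawn Z in compound 1 and E in compound 3. In a functional assay on U-87MG ATCC cells (Homo sapiens) for cytotoxicity, read by MTT assay, with a stated time of 48 h (a higher number here means a weaker inhibitor, a lower number a stronger inhibitor), compound 1 gives 5 nM, and compound 3 gives 5 nM; the comparison shows no change at the digits printed from compound 1 to compound 3 (within the scatter), a result that sits beside (the fact that compounds 1 and 3 differ only in the configuration as drawn). Compound 2 `C/C(=N/NC(=S)Nc1ccccc1)c1ccccn1` is made from compound 1 by a single change, (hydrogen in place of fluoro on an aromatic carbon), and in this assay compound 2 gives 1.4 nM, so that a 3.6-fold lower number from compound 1 to compound 2 (0.55 log units; beyond the scatter).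

Compound 4 `C/C(=N\NC(=S)Nc1ccccc1)c1ccccn1` is obtained from compound 3 by the same change, (hydrogen in place of fluoro on an aromatic carbon), made at the same place; among the four compounds this change occurs twice in all. Because no change at the digits printed from compound 1 to compound 3 (within the scatter) puts the two compounds level, the expected step of a 3.3-fold lower number from compound 3 to compound 4 (0.52 log units; beyond the scatter) in this assay is taken to be of about the same size as the measured 3.6-fold lower number from compound 1 to compound 2 (0.55 log units; beyond the scatter). On that basis compound 4 is estimated to give 1.5 nM in this assay, with a likely range from 0.6 nM to 4 nM.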

Compound 4, half-maximal inhibitory concentration: 1.4 nM
Estimate against measurement, compound 4: 1.1-fold (0.03 log units) above, within the range that was stated.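

In this assay, hydrogen in place of fluoro gives a 3.6-fold lower number from compound 3 to compound 4 (0.55 log units; beyond the scatter), which matches the step seen on the other drawn configuration: the same change on two cores in this assay, a 3.6-fold lower number (0.55 log units; beyond the scatter) from compound 1 to compound 2 and a 3.6-fold lower number (0.55 log units; beyond the scatter) from compound 3 to compound 4, 1.0-fold (0.00 log units) apart, within the scatter of two such steps. The two compounds without the fluoro also stand level, with no change at the digits printed from compound 2 to compound 4 (within the scatter): the fact that compounds 2 and 4 differ only in the configuration as drawn. Going by these compounds alone, the change therefore carries from one drawn configuration of this double bond to the other, but these are only two cases on cores with the same atoms and bonds, so this does not show that it would carry to a core that differs in its atoms or bonds, nor does it explain why the step occurs.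

The compounds shown leave open whether chloro, methyl or methoxy at the same place would give a step of similar size. They also leave open whether an amine or a carboxylic acid elsewhere on the shared core would leave this step intact.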